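The compounds below may be only part of what the source reports. "The series", "measured", "known", "first", "only" and "open" are said of these compounds alone.

Of the compounds shown here, two have been measured in a functional assay on NCI-H322M cells (Homo sapiens) for inhibition; on this read-out higher numbers stand for weaker inhibition of growth and lower numbers for stronger inhibition of growth. Compound 1 `COc1cc(/C=C/C(=O)c2cccc(-n3cc(-c4ccc(Cl)cc4)[nH]c3=O)c2)ccc1O` gives 4580 nM in this assay. Compound 2 `COc1cc(/C=C/C(=O)c2cccc(-n3cc(-c4ccccc4)[nH]c3=O)c2)cc(OC)c1OC` gives 2020 nM in this assay, the lowest of the two numbers, and the gap to compound 1 lies beyond the scatter. Compound 3 `COc1cc(/C=C/C(=O)c2cccc(-n3cc(-c4cc(OC)c(OC)c(OC)c4)[nH]c3=O)c2)cc(OC)c1OC` is not yet measured. It differs from compound 2 in one place: 3,4,5-trimethoxyphenyl in place of phenyl on an aromatic carbon. Within the data shown here, no measured pair shows this change, so its effect is unknown. The step from compound 2 to compound 3 is expected to be small, a 1.6-fold lower number from compound 2 to compound 3 (0.19 log units; within the scatter), at most a modest fall in the number. Compound 3 is therefore estimated at 1300 nM, within a range from 400 nM to 4500 nM.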

Compound 3, concentration for 50% growth inhibition: 3610 nM
For compound 3 the middle estimate is 2.8-fold (0.44 log units) below the measured one; measured number inside the range.
By their numbers in this assay, from the lowest: compounds 2, 3 and 1 (each within the scatter of the next, the first and the last beyond it).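

In this assay, placing 3,4,5-trimethoxyphenyl instead of phenyl on this aromatic carbon gives a 1.8-fold higher number from compound 2 to compound 3 (0.25 log units; within the scatter). The position therefore takes the larger group, with its added oxygen atoms, and the assay cannot tell the two compounds apart. Nothing measured here offers an explanation for this result. Going by these compounds, whether this position tolerates very different groups remains open, since only these two aromatic rings are compared there. A small methyl group, or a phenyl ring carrying an amine or a carboxylic acid, could still give a clearly different number.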